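Replacing 4-ethoxyphenyl with 3-carboxy-4-methoxyphenyl on one core

A few compounds are considered here, and "the series" means these few. Any claim that something is new, unique, unknown or untested is made for them only; others in the source may bear on it.

Of the compounds shown here, two have been tested so far in a functional assay on A549 cells (Homo sapiens) for antiproliferative activity, read by MTT assay, with a stated time of 48 h; on this read-out higher numbers stand for weaker inhibition and lower numbers for stronger inhibition. Compound 1 `COc1ccc(-c2cncc3[nH]c(=O)n(Cc4cc(OC)c(OC)c(OC)c4)c23)cc1O` gives > 20000 nM, which is a limit of the assay and not a number. For the measured compounds named here, compound 2 `CCOc1ccc(-c2cc3c(cn2)[nH]c(=O)n3-c2cc(OC)c(OC)c(OC)c2)cc1` gives 5300 nM, and this is the only true number available, so it has nothing measured to be ranked against.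

Compound 3 `COc1ccc(-c2cc3c(cn2)[nH]c(=O)n3-c2cc(OC)c(OC)c(OC)c2)cc1C(=O)O` keeps the core of compound 2 but carries 3-carboxy-4-methoxyphenyl in place of 4-ethoxyphenyl on an aromatic carbon, next to the ring nitrogen: 3-carboxy-4-methoxyphenyl in place of 4-ethoxyphenyl on an aromatic carbon. This is a single change, so any shift in this assay can be read against one starting point.

Going by the values given here, no measured pair of compounds shows what a change of this kind does, so the expectation is cautious and rests on compound 2 at 5300 nM as the sole anchor. A moderate loss of inhibition is expected, with the estimated move being a 2.6-fold higher number from compound 2 to compound 3 (0.42 log units; beyond the scatter). The assay may also report only a limit. For compound 3 the expected value is 14000 nM, with an estimated range of 5000 nM to 40000 nM.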

Compound 3, half-maximal inhibitory concentration: 1280 nM
Compound 3: the middle estimate sits 11-fold (1.04 log units) above what was measured; measured number outside the range, below it.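

At the aromatic carbon next to the ring nitrogen, this assay shows that replacing 4-ethoxyphenyl with 3-carboxy-4-methoxyphenyl gives a 4.1-fold lower number from compound 2 to compound 3 (0.62 log units; beyond the scatter), a modest gain in inhibition that lies beyond the scatter. For the compounds shown here, this is the first comparison here between two compounds differing in one place, and it shows that this position can carry a ring bearing a carboxy group without losing inhibition in this cell assay. Compound 1 offers no such comparison, and its value is a limit and not a number: the limit of > 20000 nM in this assay, at which 1 of the 3 values shown sits.

The swap alters two things at once, adding the carboxy group and exchanging ethoxy for methoxy, so the gain cannot be assigned to either one, and the compounds shown give no reason for it. As far as these compounds go, a methyl ester or an amide in place of the carboxy group, or a longer chain on the ring oxygen, would help separate these two contributions, and it also remains open whether the same swap would have a similar effect on a different core.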